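Pyrimidin-2-yl for 3-fluorophenyl: clearance notes

This account rests on a few compounds, and the source may have more. Where it says the series, first, only, none or still open, it means among the compounds named here.

- compound 1 `C[C@H](NC(=O)c1ncccn1)c1ccc(NC(=O)N2CC(c3ccc(N)nc3)C2)cc1`: < 25 mL.min-1.g-1
- compound 2 `C[C@H](NC(=O)c1cccc(F)c1)c1ccc(NC(=O)N2CC(c3cncc(N)c3)C2)cc1`: 27.4 mL.min-1.g-1

Going by the values given here, in an ADME assay on microsomes from liver (Mus musculus) for pharmacokinetics, read by LC-MS, using NADPH, with stated times of 5 min, 15 min and 30 min, tested at 10 uM (on this read-out higher numbers stand for fast clearance and lower numbers for slow clearance), compound 2 gives 27.4 mL.min-1.g-1, the only true number so far. Compound 1, with < 25 mL.min-1.g-1, is reported as a limit of the assay. Compound 3 `C[C@H](NC(=O)c1ncccn1)c1ccc(NC(=O)N2CC(c3cncc(N)c3)C2)cc1` differs from compound 2 as follows: pyrimidin-2-yl in place of 3-fluorophenyl on a carbonyl carbon. Compound 1 also bears pyrimidin-2-yl on a carbonyl carbon, and its limit of < 25 mL.min-1.g-1 points towards slower clearance. The expected change is small, a 1.4-fold lower number from compound 2 to compound 3 (0.14 log units; within the scatter), in that same direction. For compound 3 the estimated value is 20 mL.min-1.g-1, with an expected range from 10 mL.min-1.g-1 to 35 mL.min-1.g-1.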

Compound 3, intrinsic clearance in microsomes: 83.4 mL.min-1.g-1
Estimate against measurement, compound 3: 4.2-fold (0.62 log units) below; measured number outside the range, above it.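

In this assay, pyrimidin-2-yl alone does not carry a low reading: on a carbonyl carbon, pyrimidin-2-yl in place of 3-fluorophenyl gives a 3.0-fold higher number from compound 2 to compound 3 (0.48 log units; beyond the scatter). With pyrimidin-2-yl kept, the amino pyridine also matters: 5-aminopyridin-3-yl in place of 6-aminopyridin-3-yl on a saturated ring carbon gives an at least 3.3-fold higher number from compound 1 to compound 3 (0.52 log units; beyond the scatter). Compound 1 is a limit of the assay, not a number, and that second step is only a bound: the limit of < 25 mL.min-1.g-1 in this assay, at which 1 of the 3 values shown sits.

Still open, on these data alone, is whether the 3-fluorophenyl step holds with 6-aminopyridin-3-yl on the saturated ring carbon. Also open, as far as these compounds go, is how an amine or a longer chain would read in place of pyrimidin-2-yl.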